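Trading trifluoromethyl for methyl: expected cytotoxicity of compound 4

This account rests on a few compounds, and the source may have more. Where it says the series, first, only, none or still open, it means among the compounds named here.

Measured so far in an ADME assay on MT4 cells (Homo sapiens) for cytotoxicity, read by MTT assay, with a stated time of 4 days; on this read-out lower numbers stand for higher toxicity in this test and higher numbers for lower toxicity in this test:
- compound 1 `Cc1cc(-c2ccc(C#N)cc2)cc(C)c1Nc1ccnc(Nc2ccc(C#N)cc2)n1`: 2080 nM
- compound 2 `COc1ccccc1-c1cc(C)c(Nc2ccnc(Nc3ccc(C#N)cc3)n2)c(C)c1`: 940 nM
- compound 3 `Cc1cc(-c2ccccc2C(F)(F)F)cc(C)c1Nc1ccnc(Nc2ccc(C#N)cc2)n1`: 4210 nM

Compound 3 stands at the highest of the three numbers in this assay; the two steps that lead to it are a 2.0-fold higher number from compound 1 to compound 3 (0.31 log units; beyond the scatter) and a 4.5-fold higher number from compound 2 to compound 3 (0.65 log units; beyond the scatter), both modest but beyond the scatter. The remaining measured step, a 2.2-fold lower number from compound 1 to compound 2 (0.34 log units; beyond the scatter), is of similar size, so all three variants of the pendant arene sit within a narrow band.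

Compound 4 `Cc1ccccc1-c1cc(C)c(Nc2ccnc(Nc3ccc(C#N)cc3)n2)c(C)c1` differs from compound 3 by methyl in place of trifluoromethyl on an aromatic carbon. For the measured compounds named here, no measured step exchanges these two groups directly. The step that bears on it most is the exchange at the same position, a 4.5-fold higher number from compound 2 to compound 3 (0.65 log units; beyond the scatter), which shows that a change of the ortho group can move this assay by a modest amount. Compound 4 is therefore expected to fall between compound 2 and compound 3, with an expected step of a 1.7-fold lower number from compound 3 to compound 4 (0.23 log units; within the scatter) that may well stay within the scatter. Compound 4 is estimated at 2500 nM, with a range from 1000 nM to 6000 nM.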

Compound 4, half-maximal cytotoxic concentration: 3820 nM
Estimate against measurement, compound 4: 1.5-fold (0.18 log units) below; measured number inside the range.
By their numbers in this assay, from the lowest: compound 2; then compounds 1, 4 and 3 (each within the scatter of the next, the first and the last beyond it).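

In this assay, methyl in place of trifluoromethyl gives a 1.1-fold lower number from compound 3 to compound 4 (0.04 log units; within the scatter), so these two groups cannot be told apart at this position. Methoxy is the one that stands apart from methyl there, with a 4.1-fold higher number from compound 2 to compound 4 (0.61 log units; beyond the scatter), while the exchange of the whole aryl group gives a 1.8-fold higher number from compound 1 to compound 4 (0.26 log units; within the scatter), so 2-methylphenyl cannot be separated from 4-cyanophenyl either. Nothing in the data given here explains these differences in cytotoxicity.

The compounds shown leave open whether a hydroxyl group or an amine at this position would group with methoxy or with methyl and trifluoromethyl in this assay. They also leave open whether a longer chain, such as ethyl, would keep the number of compound 4.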